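N-Methylation of a Ring Amide in a Cyclic Peptide Series

A few compounds are considered here, and "the series" means these few. Any claim that something is new, unique, unknown or untested is made for them only; others in the source may bear on it.

The three measured compounds, all run in a functional assay (plasma) for inhibition, with Canis familiaris (Canis lupus familiaris) as the target; on this read-out higher numbers stand for weaker inhibition and lower numbers for stronger inhibition:
compound 1 `CC(=O)N[C@@H]1CSSC(C)(C)[C@H](C(N)=O)NC(=O)[C@@H](CC(=O)O)NC(=O)CN(C)C(=O)[C@@H](CCCN=C(N)N)NC1=O` gives 73400 nM
compound 2 `CC(=O)N[C@@H]1CSSC(C)(C)[C@H](C(N)=O)NC(=O)[C@@H](CC(=O)O)N(C)C(=O)CNC(=O)[C@@H](CCCN=C(N)N)NC1=O` gives 137000 nM
compound 3 `CC(=O)N[C@@H]1CSSC(C)(C)[C@H](C(N)=O)NC(=O)[C@@H](CC(=O)O)NC(=O)CN(C)C(=O)[C@@H](CCCN=C(N)N)N(C)C1=O` gives 39500 nM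

Compound 3 arises from compound 1 by methyl in place of hydrogen on an amide-type nitrogen in a ring, and this step gave a 1.9-fold lower number from compound 1 to compound 3 (0.27 log units; within the scatter). Compound 2 and compound 1 have the same atoms joined differently; the difference between the two cores is not broken down here. Compound 2 has the highest number of the three; its gap to compound 3 lies beyond the scatter, while its gap to compound 1 does not.

Compound 4 `CC(=O)N[C@@H]1CSSC(C)(C)[C@H](C(N)=O)NC(=O)[C@@H](CC(=O)O)N(C)C(=O)CNC(=O)[C@@H](CCCN=C(N)N)N(C)C1=O` has not yet been measured in this assay. It arises from compound 2 by methyl in place of hydrogen on an amide-type nitrogen in a ring. Going by the values given here, this is the same kind of change as the one from compound 1 to compound 3, though not the same: around the place in compound 1 there is a ring atom that bears a methyl group three ring bonds away and a ring atom that bears two methyl groups six ring bonds away, whereas in compound 2 the ring atom six ring bonds away bears a methyl group. Because a 1.9-fold lower number from compound 1 to compound 3 (0.27 log units; within the scatter) was seen for the same kind of change, compound 2 is expected to move by a 1.9-fold lower number from compound 2 to compound 4 (0.28 log units; within the scatter) in this assay, with a single precedent leaving the step uncertain. Compound 4 is thus estimated at 72000 nM, between 30000 nM and 170000 nM.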

Compound 4, half-maximal inhibitory concentration: 23400 nM
For compound 4 the middle estimate is 3.1-fold (0.49 log units) above the measured one; the measured number lies below the stated range.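

In this assay, methyl in place of hydrogen on the amide-type nitrogen gave a 5.9-fold lower number from compound 2 to compound 4 (0.77 log units; beyond the scatter), so on the core of compound 2 the change has a clear effect on the read-out. Set beside the earlier step, the size of this change does not carry over unaltered from one core to the other: the same change on two cores in this assay, a 1.9-fold lower number (0.27 log units; within the scatter) from compound 1 to compound 3 and a 5.9-fold lower number (0.77 log units; beyond the scatter) from compound 2 to compound 4, 3.2-fold (0.50 log units) apart, beyond the scatter of two such steps

This shows that a step read on one core is a poor guide to the size of the step on the other, but it does not show which difference between the two cores, which have the same atoms joined differently, accounts for the gap, and two cores give no rule for a third. Still open, on these data alone, is how an ethyl group or a longer chain on this same nitrogen would read on either core. As far as these compounds go, it is also open whether the step would keep its size with an amide in place of the carboxylic acid of the carboxymethyl group.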